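Cytotoxicity notes: benzylamino-piperazine variants on a nitro core

The compounds below may be only part of what the source reports. "The series", "measured", "known", "first", "only" and "open" are said of these compounds alone.

Measured so far:
compound 1 `O=c1nc(N2CCN(NCC3CCCCC3)CC2)sc2c([N+](=O)[O-])cc(C(F)(F)F)cc12` – 29.3 ug/mL
compound 2 `O=c1nc(N2CCN(NCc3ccc(F)cc3)CC2)sc2c([N+](=O)[O-])cc(C(F)(F)F)cc12` – > 64 ug/mL

In an ADME assay on Vero cells (Chlorocebus sabaeus) for cytotoxicity, read by MTT assay, with a stated time of 72 h (on this read-out lower numbers stand for higher toxicity in this test and higher numbers for lower toxicity in this test), compound 1 gives 29.3 ug/mL. For compound 2 the read-out is a limit of the test, (the limit of > 64 ug/mL in this assay, at which 1 of the 2 values shown sits), so it has no fixed number. Among the compounds with values here, the single measured step, an at least 2.1-fold higher number from compound 1 to compound 2 (0.33 log units; beyond the scatter), ends at that limit. Compound 3 `CC(C)(C)c1ccc(CNN2CCN(c3nc(=O)c4cc(C(F)(F)F)cc([N+](=O)[O-])c4s3)CC2)cc1` differs from compound 2 by tert-butyl in place of fluoro on an aromatic carbon. Within the data shown here, no measured step covers this change, and the step ending in compound 2 gives only a floor. The number expected for compound 3 is therefore uncertain in direction; the estimate is 45 ug/mL, meaning an expected at least 1.4-fold lower number from compound 2 to compound 3 (0.15 log units; that floor lies within the scatter), with a fair chance that only a limit is again reported.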

Compound 3, half-maximal cytotoxic concentration: > 64 ug/mL
Compound 3: only a limit was reported; the forecaster's own chance of this, stated with the estimate: 40%; at least 1.4-fold (0.15 log units) between middle value and limit.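

In this assay the read-out for compound 3 is again a limit of the test and not a number: the limit of > 64 ug/mL in this assay, at which 2 of the 3 values shown sit. With both ends at limits, the step from fluoro to tert-butyl cannot be read. The comparison with cyclohexyl can be read, with an at least 2.1-fold higher number from compound 1 to compound 3 (0.33 log units; beyond the scatter), so the step seen with 4-fluorophenyl recurs with 4-(tert-butyl)phenyl.

From the compounds shown here alone, it remains open whether any group on this aromatic carbon, such as an amine or a carboxylic acid, gives a number inside the range of the test.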